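Series notes: replacing the chain amine of compound 1

The source may hold more compounds than are shown below. What is called first, only, known or untested is meant among the compounds shown, and "the series" means these compounds.

Compound 1 `Cn1ncc(Cl)c1-c1cc(C(=O)N[C@@H]2CN[C@H](CCN3CCC(O)CC3)C[C@H]2c2ccc(Cl)c(Cl)c2)oc1Cl` is the reference for this step. Going by the values given here, in a functional assay on LNCaP cells (Homo sapiens) for antiproliferative activity (a higher number here means a weaker inhibitor, a lower number a stronger inhibitor), compound 1 gives 1140 nM, which is the second highest of the three numbers measured so far. Its closest neighbour is compound 3 `Cn1ncc(Cl)c1-c1cc(C(=O)N[C@@H]2CN[C@H](CCN3CCCC3)C[C@H]2c2ccc(Cl)c(Cl)c2)oc1Cl`, which gives 1920 nM; the step of a 1.7-fold higher number from compound 1 to compound 3 (0.23 log units; within the scatter) stays within the scatter. Far from both is compound 2 `Cn1ncc(Cl)c1-c1cc(C(=O)N[C@@H]2CN[C@H](CCn3cncn3)C[C@H]2c2ccc(Cl)c(Cl)c2)oc1Cl`, which gives 60 nM; here the step of a 19-fold lower number from compound 1 to compound 2 (1.28 log units; beyond the scatter) is large, and the step of a 32-fold higher number from compound 2 to compound 3 (1.51 log units; beyond the scatter) is of the same order in the other direction.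

Compound 4 `COCC[C@@H]1C[C@@H](c2ccc(Cl)c(Cl)c2)[C@H](NC(=O)c2cc(-c3c(Cl)cnn3C)c(Cl)o2)CN1` is the next compound. It differs from compound 1 in one place: methoxy in place of 4-hydroxypiperidin-1-yl on a saturated chain carbon, two bonds along the chain from a saturated ring carbon

Among the compounds with values here, no measured step matches this change. The two steps that start from compound 1 show what is possible at this position: a change within the scatter when pyrrolidin-1-yl enters, and a large drop in the number when 1H-1,2,4-triazol-1-yl enters. Methoxy is smaller than either group and has no ring, so the outcome is open. Taking a position between those two results, compound 4 is expected to give 400 nM, within a range of 100 nM to 1600 nM, an estimated step of a 2.9-fold lower number from compound 1 to compound 4 (0.45 log units; beyond the scatter) that would be beyond the scatter but well short of what compound 2 showed.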

Compound 4, half-maximal inhibitory concentration: 250 nM
Compound 4: the middle estimate sits 1.6-fold (0.20 log units) above what was measured, and the stated range covers the measured number.
By their numbers in this assay, from the lowest: compound 2; then compound 4; then compounds 1 and 3 (each within the scatter of the next).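

In this assay, the methoxy compound sets a third level at this position, with a 4.6-fold lower number from compound 1 to compound 4 (0.66 log units; beyond the scatter) and a 7.7-fold lower number from compound 3 to compound 4 (0.89 log units; beyond the scatter) both beyond the scatter, while a 4.2-fold higher number from compound 2 to compound 4 (0.62 log units; beyond the scatter) is also beyond the scatter in the other direction. A group with no ring on the saturated chain carbon, two bonds along the chain from a saturated ring carbon, therefore separates from both 4-hydroxypiperidin-1-yl and pyrrolidin-1-yl, so a ring in this place is not needed for a lower number, and 1H-1,2,4-triazol-1-yl remains the one group shown that gives a lower number than methoxy. No supporting measurement bears on why these four groups fall in this order.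

The compounds shown leave open how a hydroxyl, an open-chain amine such as dimethylamino or a longer ether such as ethoxy would fall among these levels on the same chain. They also leave open whether imidazol-1-yl or another aromatic ring containing nitrogen would match the result for 1H-1,2,4-triazol-1-yl.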